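The source may report more compounds than this note shows. Statements on the series, on what has been measured and on what is new or still open speak of the compounds shown alone.

In a functional assay on HeLa cells (Homo sapiens) for antiproliferative activity, read by MTT assay, with a stated time of 48 h (a lower number here means a stronger inhibitor, a higher number a weaker inhibitor), compound 1 (`COc1cc(-c2nnc3c(OC)cc(-c4ccc5[nH]ccc5c4)cn23)cc(OC)c1OC`) gives 85 nM, compound 2 (`COc1cc(-c2nnc3c(OC4COC4)cc(-c4ccc5[nH]ccc5c4)cn23)cc(OC)c1OC`) gives 2780 nM and compound 3 (`COc1cc(-c2nnc3c(OCC(F)(F)F)cc(-c4ccc5[nH]ccc5c4)cn23)cc(OC)c1OC`) gives 348 nM. Compound 3 therefore stands second highest of the three numbers, with compound 1 lower and compound 2 higher.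

Next in the series is compound 4 (`COc1cc(-c2nnc3c(OC4CCC4)cc(-c4ccc5[nH]ccc5c4)cn23)cc(OC)c1OC`), and the change is cyclobutyl in place of 2,2,2-trifluoroethyl on an oxygen on an aromatic ring. All three measured steps concern the group on this same oxygen. Replacing methyl raised the number both times, with a 33-fold higher number from compound 1 to compound 2 (1.51 log units; beyond the scatter) and a 4.1-fold higher number from compound 1 to compound 3 (0.61 log units; beyond the scatter). The step between the two larger groups is also beyond the scatter, at an 8.0-fold lower number from compound 2 to compound 3 (0.90 log units; beyond the scatter), so the size of a step here depends strongly on the group. For the measured compounds named here, no measured compound carries cyclobutyl, which leaves the direction poorly fixed.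

In this assay no step beyond the scatter is expected, with a slight lean towards a higher number. The estimated step is a 1.4-fold higher number from compound 3 to compound 4 (0.14 log units; within the scatter). For compound 4 the expected value is 480 nM, with an estimated range of 140 nM to 1600 nM.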

Compound 4, half-maximal inhibitory concentration: 142 nM
Compound 4: middle estimate off by 3.4-fold (0.53 log units), on the high side; measured number inside the range.
By their numbers in this assay, from the lowest: compounds 1 and 4 (each within the scatter of the next); then compound 3; then compound 2.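

In this assay, a group larger than methyl on this oxygen can sit level with methyl: cyclobutyl gives (a 1.7-fold higher number from compound 1 to compound 4 (0.22 log units; within the scatter)), so the losses seen with oxetan-3-yl and 2,2,2-trifluoroethyl do not hold for every replacement. The two four-membered rings part widely, with (a 20-fold lower number from compound 2 to compound 4 (1.29 log units; beyond the scatter)), so having a four-membered ring on this oxygen does not by itself set the number, and the carbon-only ring also reads better than the fluorinated chain (a 2.5-fold lower number from compound 3 to compound 4 (0.39 log units; beyond the scatter)). Nothing measured here accounts for these steps.

The compounds shown leave open how ethyl, cyclopentyl or an aminoethyl chain on this oxygen would read. It therefore stays unclear whether the ring or the absence of fluorine matters more for the result with cyclobutyl.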